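Swapping Trifluoromethyl for Methyl on the Amide Ring

The compounds below may be only part of what the source reports. "The series", "measured", "known", "first", "only" and "open" are said of these compounds alone.

Compound 1, `Cc1cn(-c2cc(NC(=O)c3ccc(C)c(Nc4nc(-c5cccnc5)cs4)c3)cc(C(F)(F)F)c2)cn1`, gives 28 nM in a functional assay on K562 cells (Homo sapiens) for antiproliferative activity; a lower number here means a stronger inhibitor, a higher number a weaker inhibitor.
Compound 2, `Cc1ccc(C(=O)Nc2cc(-n3ccnc3)cc(C(F)(F)F)c2)cc1Nc1nc(-c2cccnc2)cs1`, gives 28 nM.
Compound 3, `Cc1ccc(C(=O)Nc2cc(-c3cnn(C)c3)cc(C(F)(F)F)c2)cc1Nc1nc(-c2cccnc2)cs1`, gives 27 nM.

The three measured compounds share one core and differ only in the small five-membered ring attached to the amide-bearing ring. Compound 1 stands level with compound 2, the two together giving the highest numbers of the three, and compound 3 sits within the scatter of both: no change at the digits printed from compound 1 to compound 2 (within the scatter), a 1.0-fold lower number from compound 1 to compound 3 (0.02 log units; within the scatter) and a 1.0-fold lower number from compound 2 to compound 3 (0.02 log units; within the scatter) are all too small to count. Compound 4, `Cc1cc(NC(=O)c2ccc(C)c(Nc3nc(-c4cccnc4)cs3)c2)cc(-n2cnc(C)c2)c1`, changes a different position: methyl in place of trifluoromethyl on an aromatic carbon. Among the measured compounds shown here, no measured step touches this trifluoromethyl group, so the three steps say only that the core tolerates variation elsewhere without moving the number. An effect beyond the scatter cannot be ruled out in either direction; a modest weakening is judged somewhat more likely than none. Compound 4 is therefore expected to give about 80 nM, within 20 nM to 400 nM, a step of a 2.9-fold higher number from compound 1 to compound 4 (0.46 log units; beyond the scatter).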

Compound 4, half-maximal inhibitory concentration: 449 nM
For compound 4 the middle estimate is 5.6-fold (0.75 log units) below the measured one; measured number outside the range, above it.
By their numbers in this assay, from the lowest: compounds 3, 1 and 2 (each within the scatter of the next); then compound 4.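

In this assay, among the compounds shown here, this position turns out to be far more sensitive than the earlier compounds suggested: putting methyl in place of trifluoromethyl gives a 16-fold higher number from compound 1 to compound 4 (1.21 log units; beyond the scatter). The three earlier compounds differ only in the five-membered ring group and stay within the scatter of one another, so they gave no sign that a single change at this other position could move the number so much. Nothing available here explains why the number rises.

The compounds shown leave open what a group at this position needs in order to keep the lower number, since a chlorine atom, a nitrile, a methoxy group or plain hydrogen would each test this differently. They also leave open whether the same swap would have a similar effect with the 1H-imidazol-1-yl group of compound 2 or the 1-methyl-1H-pyrazol-4-yl group of compound 3.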